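This account rests on a few compounds, and the source may have more. Where it says the series, first, only, none or still open, it means among the compounds named here.

Compound 3 `COC(=O)[C@H](CCSC)NC(=O)c1ccc(NCc2cncn2Cc2cccc(Cl)c2)cc1-c1ccccc1` stands at the boundary of what a functional assay on NIH3T3 cells (Mus musculus) (a lower number here means that less compound is needed, a higher number that more compound is needed for the effect), can report. In this assay compound 3 gives > 10 uM, which is a limit of the assay and not a number. Compound 2 `CSCC[C@H](NC(=O)c1ccc(NCc2cncn2Cc2cccc(Cl)c2)cc1-c1ccccc1)C(=O)O` gives > 10 uM, again a limit. Compound 1 `COC(=O)[C@H](CCSC)NC(=O)c1ccc(CNCc2cncn2Cc2ccc(C#N)cc2)cc1-c1ccccc1C` gives > 10 uM, also a limit. Going by the values given here, the one step between two measured compounds, a step that the two limits leave unreadable from compound 2 to compound 3, cannot be read, as follows from the limit of > 10 uM in this assay, at which 3 of the 3 values shown sit. Compound 4 `COC(=O)[C@H](CCSC)NC(=O)c1ccc(NCc2cncn2Cc2ccccc2C)cc1-c1ccccc1` brings a different change, (2-methylphenyl in place of 3-chlorophenyl on a saturated chain carbon bound to an aromatic nitrogen). Among the compounds with values here, no measured step bears on this change, and no step of readable size exists among the three measured compounds. The expectation for compound 4 rests on compound 3, whose value in this assay is a limit, so the most likely outcome is another limit. The expected step is a step that the limit leaves unreadable from compound 3 to compound 4, which is no step beyond the scatter. Compound 4 is estimated at 15 uM, with a range from 4 uM to 60 uM.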

Compound 4, concentration for half-maximal effect: > 10 uM
Compound 4 was reported as a limit (the forecaster's own chance of this, stated with the estimate: 75%); the middle value is on the limit's open side.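

In this assay compound 4 gives > 10 uM, which is a limit and not a number. Going by these compounds alone, no step from compound 3 to compound 4 can therefore be read: the limit of > 10 uM in this assay, at which 4 of the 4 values shown sit. The compounds shown leave open whether 3-chlorobenzyl and 2-methylbenzyl differ at all in this assay.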